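Adding a hydroxy group to compound 2

The source may hold more compounds than are shown below. What is called first, only, known or untested is meant among the compounds shown, and "the series" means these compounds.

Among the measured compounds shown here, only two compounds have numbers so far in a functional assay on the whole organism (Hindlimb, strain albino) with Mus musculus as the target, in the maximal electroshock model, with a stated time of 0.5 h; a higher number here means that more compound is needed for the effect, a lower number that less compound is needed. Compound 1 (`O=C(/C=C/c1ccc(O)cc1)Nc1nc2ccccc2s1`) gives 517 umol/kg and compound 2 (`O=C(/C=C/c1ccccc1)Nc1nc2ccc([N+](=O)[O-])cc2s1`) gives 485 umol/kg in that test, and the two values lie within the usual scatter of each other. For the measured compounds named here, compound 2 therefore stands level with the only other measured compound.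

Compound 3 (`O=C(/C=C/c1ccc(O)cc1)Nc1nc2ccc([N+](=O)[O-])cc2s1`) keeps the core of compound 2 and takes hydroxy in place of hydrogen on an aromatic carbon, para to a large group, counted as hydroxy in place of hydrogen on an aromatic carbon in the change from phenyl to 4-hydroxyphenyl. Going by the values given here, no measured pair shows this change alone, so its size in this assay has no direct precedent. Among the compounds with values here, the one indirect guide is compound 1, which carries the same 4-hydroxyphenyl group and sits at 517 umol/kg in the same range as compound 2. No step beyond the scatter is therefore expected, and the estimated change is small, with a 1.1-fold lower number from compound 2 to compound 3 (0.03 log units; within the scatter) as the expected step. For compound 3 the estimated value is 450 umol/kg with an expected range from 220 umol/kg to 900 umol/kg in this test.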

Compound 3, dose for half-maximal effect: 382 umol/kg
The estimate for compound 3 lay 1.2-fold (0.07 log units) above the measured number; low and high end bracket the measured number.
By their numbers in this assay, from the lowest: compounds 3, 2 and 1 (each within the scatter of the next).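

In this assay, hydroxy in place of hydrogen on an aromatic carbon, para to a large group, now has a direct reading on the core of compound 2: a 1.3-fold lower number from compound 2 to compound 3 (0.10 log units; within the scatter), so the change from phenyl to 4-hydroxyphenyl does not move the number outside the scatter. The second pair holds the 4-hydroxyphenyl group fixed and reads nitro in place of hydrogen on an aromatic carbon, with a 1.4-fold lower number from compound 1 to compound 3 (0.13 log units; within the scatter), so this change also stays within the scatter, and compound 1, compound 2 and compound 3 stand level in this test. No supporting measurement is available to explain why either change leaves the number level.

An amine, a methoxy group or a carboxylic acid at the same place on the six-membered aromatic ring could still give a step beyond the scatter, and the compounds shown do not settle this. From the compounds shown here alone, the reading of each change also comes from one pair only, so it remains open whether the same small step would hold for the core without either hydroxy or nitro.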